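Replacing a halogenated phenyl with a carboxylated one

A few compounds are considered here, and "the series" means these few. Any claim that something is new, unique, unknown or untested is made for them only; others in the source may bear on it.

Compound 1 `O=C1c2ccc(OCc3cccc(-c4ccc(Cl)cc4F)c3)cc2CN1C1CCCC1` gives "not determined" (no result reported) in an assay on HEK293 cells for positive allosteric modulation of metabotropic glutamate receptor 2 (Rattus norvegicus), read by thallium flux; a higher number here means a larger maximal response, a lower number a smaller maximal response; its result was not reported. Compound 2 `CC(C)CCn1sc2cc(OCc3cccc(-c4ccc(Cl)c(C(=O)O)c4)c3)ccc2c1=O`, built on a different core but carrying a carboxy group on its outer phenyl, gives 67.3% in this assay. Compound 3 `O=C(O)c1cc(F)cc(-c2cccc(COc3ccc4c(c3)CN(C3CCCC3)C4=O)c2)c1` differs from compound 1 in one place: 3-carboxy-5-fluorophenyl in place of 4-chloro-2-fluorophenyl on an aromatic carbon. Among the measured compounds shown here, with no measured value for compound 1, no size or direction for this step can be drawn from the data; the only anchor is compound 2. Compound 3 is therefore expected to reach about 60% in this assay, within a range from 35% to 90%.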

Compound 3, largest response reached (reported as percent of maximum), in percent of the reference or control that the assay uses: 80.8%
Compound 3: middle estimate off by 20.8 percentage points, on the low side; the range from low to high includes it.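

Among the compounds shown here, with compound 1 at "not determined" (no result reported) and compound 3 at 80.8% no step between the two can be read. As far as these compounds go, what 3-carboxy-5-fluorophenyl in place of 4-chloro-2-fluorophenyl does to the maximal response stays open. No further data bear on this result.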